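Swapping Methoxy for Chloro: Cytotoxicity Outlook for Compound 4

A few compounds are considered here, and "the series" means these few. Any claim that something is new, unique, unknown or untested is made for them only; others in the source may bear on it.

Three compounds built on one shared core have been run in an ADME assay on HEK293 cells (Homo sapiens) for cytotoxicity, read by CellTiter-Glo and resazurin assay, with a stated time of 72 h; on this read-out lower numbers stand for an effect already at smaller amounts and higher numbers for an effect only at larger amounts of compound. Compound 1 `CC(C)N(Cc1cccc(OCCCCCC(=O)O)c1)C(=O)c1ccc(-c2cccc3ccccc23)cc1` returns only a limit of > 26000 nM in this assay. Compound 2 `CC(C)N(Cc1cccc(OCCCCCC(=O)O)c1)C(=O)c1ccc(-c2ccco2)cc1` likewise returns only a limit, > 26000 nM. Compound 3 `COc1cccc(-c2ccc(C(=O)N(Cc3cccc(OCCCCCC(=O)O)c3)C(C)C)cc2)c1` also stops at a limit, > 20900 nM, so it stands among values that all say the same thing: no toxic effect was seen up to the highest amount tested. The steps a step that the two limits leave unreadable from compound 1 to compound 2, a step that the two limits leave unreadable from compound 1 to compound 3 and a step that the two limits leave unreadable from compound 2 to compound 3 therefore carry no readable size, because the limit of > 20900 nM in this assay, at which 1 of the 3 values shown sits, and the limit of > 26000 nM in this assay, at which 2 of the 3 values shown sit, are all that the three values provide.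

Compound 4 `CC(C)N(Cc1cccc(OCCCCCC(=O)O)c1)C(=O)c1ccc(-c2cccc(Cl)c2)cc1` differs from compound 3 in a single place: chloro in place of methoxy on an aromatic carbon. Among the compounds with values here, since none of the measured steps shows a readable size or direction, there is no basis to expect a shift beyond the scatter, and the step that the limit leaves unreadable from compound 3 to compound 4 is expected to stay small or to remain unreadable. Compound 4 is estimated to give 30000 nM in this assay, within a range from 10000 nM to 90000 nM, with another limit being the most likely outcome.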

Compound 4, half-maximal effective concentration: > 21900 nM
Compound 4 gave a limit, no number; the forecaster's own chance of this, stated with the estimate: 80%; the middle value is on the limit's open side.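

Compound 4 also returns only a limit in this assay, like compound 1, compound 2 and compound 3, so none of the steps linking compound 4 to those three can be read. The compounds shown leave open at what amount, if any, each of these four compounds would harm the cells.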